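The source may hold more compounds than are shown below. What is called first, only, known or untested is meant among the compounds shown, and "the series" means these compounds.

Values so far in a functional assay on A549 cells (Homo sapiens) for antiproliferative activity, read by MTT assay; a higher number here means a weaker inhibitor, a lower number a stronger inhibitor
- compound 1 `COc1cc2c(Oc3ccc(NC(=O)Nc4ccccc4)cc3)ccnc2cc1OCCCCCCC(=O)NO` gives 1650 nM
- compound 2 `COc1cc2c(Oc3ccc(NC(=O)Nc4ccc(C(F)(F)F)cc4Cl)cc3)ccnc2cc1OCCCCCCC(=O)NO` gives 970 nM
- compound 3 `COc1ccccc1NC(=O)Nc1ccc(Oc2ccnc3cc(OCCCCCCC(=O)NO)c(OC)cc23)cc1` gives 16200 nM

Compound 3 holds the highest number of the three. Its steps from the others are a 9.8-fold higher number from compound 1 to compound 3 (0.99 log units; beyond the scatter) and a 17-fold higher number from compound 2 to compound 3 (1.22 log units; beyond the scatter) and both lie beyond the scatter. Between the other two the gap is a 1.7-fold lower number from compound 1 to compound 2 (0.23 log units; within the scatter) and gives no order.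

Going on to compound 4 `COc1cc2c(Oc3ccc(NC(=O)N/N=C/c4ccccc4)cc3)ccnc2cc1OCCCCCCC(=O)NO` the 2-methoxyphenyl leaves and the change is a group of 8 heavy atoms (7 carbon, 1 nitrogen; one six-membered aromatic ring of carbon only) in place of a group of 8 heavy atoms (7 carbon, 1 oxygen; one six-membered aromatic ring of carbon only), on an amide-type nitrogen with a double bond outside aromatic rings in the entering group.

The closest measured step is a 9.8-fold higher number from compound 1 to compound 3 (0.99 log units; beyond the scatter) where the methoxy appears that compound 4 no longer has. The step of a 17-fold higher number from compound 2 to compound 3 (1.22 log units; beyond the scatter) also ends at compound 3 and points the same way. Within the data shown here, no measured compound carries the entering group, so neither step can be carried over in full, and a return to the level of compound 1 is not assumed. A modest drop is expected in this assay and is estimated as a 4.6-fold lower number from compound 3 to compound 4 (0.67 log units; beyond the scatter) with wide uncertainty. For compound 4 the estimate is 3500 nM with 900 nM to 13000 nM as the expected range.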

Compound 4, half-maximal inhibitory concentration: 3700 nM
The estimate for compound 4 lay 1.1-fold (0.02 log units) below the measured number, within the range that was stated.
By their numbers in this assay, from the lowest: compounds 2 and 1 (each within the scatter of the next); then compound 4; then compound 3.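

Working notes on the amide-type nitrogen: in this assay, replacing the 2-methoxyphenyl with the entering group, which has the same count of heavy atoms, donors and acceptors and also one six-membered aromatic ring of carbon only, gives a clear shift (a 4.4-fold lower number from compound 3 to compound 4 (0.64 log units; beyond the scatter)), so those counts alone do not fix the number at this position. The entering group, with its double bond outside aromatic rings, still leaves compound 4 short of the unsubstituted phenyl (a 2.2-fold higher number from compound 1 to compound 4 (0.35 log units; beyond the scatter)) and of the 2-chloro-4-(trifluoromethyl)phenyl (a 3.8-fold higher number from compound 2 to compound 4 (0.58 log units; beyond the scatter)), so the position accepts this longer, nitrogen-containing group with only a modest loss against either. No available measurement bears on what lies behind these differences.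

Still open, on these data alone, is whether the double bond itself matters, which a saturated methylene link in its place would test. Also open, as far as these compounds go, is whether a methoxy, or chlorine with trifluoromethyl, on the ring of the entering group would move the number as these substituents do on the phenyl series, or whether a dimethylamino group there would behave differently.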